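This account rests on a few compounds, and the source may have more. Where it says the series, first, only, none or still open, it means among the compounds named here.

Compound 1, with structure `CCCCCCCOC(=O)CCC(=O)N1CCN(CCCOc2cc3c(Nc4ccc(F)c(Cl)c4)ncnc3cc2OC)CC1`, is the starting point of this short series. In a functional assay on A549 cells (Homo sapiens) for cytotoxicity, read by MTT assay, with a stated time of 24 h, tested at 40 uM (a higher number here means a weaker effect of the compound at the concentration tested, a lower number a stronger effect), compound 1 gives 59.1%. Compound 2, with structure `CCCCCCCCOC(=O)CCC(=O)N1CCN(CCCOc2cc3c(Nc4ccc(F)c(Cl)c4)ncnc3cc2OC)CC1`, differs from it by methyl in place of hydrogen on a saturated chain carbon, seven bonds along the chain from an oxygen next to a carbonyl group; in this assay compound 2 gives 48.7%, and the step of a number 10.4 percentage points lower from compound 1 to compound 2 (beyond the scatter). Compound 3, with structure `CCCCCCCCCCCCCCCCOC(=O)CCC(=O)N1CCN(CCCOc2cc3c(Nc4ccc(F)c(Cl)c4)ncnc3cc2OC)CC1`, carries a much longer chain, its difference from compound 1 being (nonyl in place of hydrogen on a saturated chain carbon, seven bonds along the chain from an oxygen next to a carbonyl group). In this assay compound 3 gives 82.6%, so a number 23.5 percentage points higher from compound 1 to compound 3 (beyond the scatter) and a number 33.9 percentage points higher from compound 2 to compound 3 (beyond the scatter); compound 3 stands highest of the three measured compounds. Compound 4, with structure `CCCCCCCCCCCCCCCCCOC(=O)CCC(=O)N1CCN(CCCOc2cc3c(Nc4ccc(F)c(Cl)c4)ncnc3cc2OC)CC1`, is still to be measured; it differs from compound 3 by methyl in place of hydrogen on a saturated chain carbon, ten or more bonds along the chain from an oxygen next to a carbonyl group. This is the same kind of change as from compound 1 to compound 2, but the place along the chain is not the same. The expected step is a number 4.6 percentage points lower from compound 3 to compound 4 (within the scatter), a guarded expectation because the earlier one-carbon step a number 10.4 percentage points lower from compound 1 to compound 2 (beyond the scatter) was modest and sat on a much shorter chain. In this assay compound 4 is estimated to give 78%.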

Compound 4, a percentage reported as activity, at one concentration (the size of the read-out at that concentration, not a potency): 85.2%
The estimate for compound 4 lay 7.2 percentage points below the measured number; low and high end bracket the measured number.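

One more methyl on the long chain gives a number 2.6 percentage points higher from compound 3 to compound 4 (within the scatter) in this assay, and this step does not stand apart from the one-carbon step on the shorter chain: the same change on two cores in this assay, a number 10.4 percentage points lower (beyond the scatter) from compound 1 to compound 2 and a number 2.6 percentage points higher (within the scatter) from compound 3 to compound 4, 13 percentage points apart, within the scatter of two such steps. The larger change, nonyl in place of hydrogen, gives a number 36.5 percentage points higher from compound 2 to compound 4 (beyond the scatter), and it too agrees with its earlier counterpart: the same change on two cores in this assay, a number 23.5 percentage points higher (beyond the scatter) from compound 1 to compound 3 and a number 36.5 percentage points higher (beyond the scatter) from compound 2 to compound 4, 13 percentage points apart, within the scatter of two such steps. Going by these compounds alone, this shows only that each change has given compatible steps on two closely related chains, not that the steps are equal or that they would hold on a different core, and the decyl change, a number 26.1 percentage points higher from compound 1 to compound 4 (beyond the scatter), has no second example here to compare with.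

The compounds shown leave open where, between the chain of compound 2 and the much longer chain of compound 3, the number starts to climb. They also leave open whether a still longer chain, or an amine or a carboxylic acid at the end of the chain, would fit the same steps.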